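Removing the ortho fluoro from compound 3

This account rests on a few compounds, and the source may have more. Where it says the series, first, only, none or still open, it means among the compounds named here.

Measured so far in an assay on isolated protein for agonist activity at Free fatty acid receptor 1 (Homo sapiens); a lower number here means that less compound is needed, a higher number that more compound is needed for the effect:
compound 1 `CC#CC(CC(=O)O)c1ccc(OCc2ccc3nc(-c4ccc(OC)cc4)cn3c2)cc1`: 47 nM
compound 2 `CC#CC(CC(=O)O)c1ccc(OCc2ccc3nc(-c4ccccc4)cn3c2)cc1`: 979 nM
compound 3 `CC#CC(CC(=O)O)c1ccc(OCc2ccc3nc(-c4ccc(F)cc4F)cn3c2)cc1`: 825 nM

Compound 3 stands second highest of the three; its number is within the scatter of compound 2 and sits far above compound 1, as an 18-fold higher number from compound 1 to compound 3 (1.24 log units; beyond the scatter) shows. Compound 4 `CC#CC(CC(=O)O)c1ccc(OCc2ccc3nc(-c4ccc(F)cc4)cn3c2)cc1` differs from compound 3 by hydrogen in place of fluoro on an aromatic carbon. The step of a 1.2-fold lower number from compound 2 to compound 3 (0.07 log units; within the scatter) shows that adding two fluoro groups to the phenyl changes nothing beyond the scatter, so taking one of them away is not expected to either. The steps of a 21-fold higher number from compound 1 to compound 2 (1.32 log units; beyond the scatter) and an 18-fold higher number from compound 1 to compound 3 (1.24 log units; beyond the scatter) are large, but both concern loss of the methoxy, which compound 4 also lacks. For compound 4 the expected step is a 1.1-fold lower number from compound 3 to compound 4 (0.04 log units; within the scatter), so compound 4 is estimated at 750 nM (300 nM to 1900 nM).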

Compound 4, half-maximal effective concentration: 623 nM
Beside the measured number, compound 4's estimate is 1.2-fold (0.08 log units) above it; low and high end bracket the measured number.
By their numbers in this assay, from the lowest: compound 1; then compounds 4, 3 and 2 (each within the scatter of the next).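

In this assay the steps of a 1.3-fold lower number from compound 3 to compound 4 (0.12 log units; within the scatter) and a 1.6-fold lower number from compound 2 to compound 4 (0.20 log units; within the scatter) keep the phenyl, the 4-fluorophenyl and the 2,4-difluorophenyl within the scatter of one another, so the fluoro ortho to a large group has no readable effect in this series. The step of a 13-fold higher number from compound 1 to compound 4 (1.12 log units; beyond the scatter) shows that 4-fluorophenyl does not stand in for 4-methoxyphenyl. No measurement at hand explains these numbers.

As far as these compounds go, whether the low number of compound 1 belongs to methoxy alone stays open: ethoxy, hydroxy or dimethylamino in its place would tell. Also open, from the compounds shown here alone, is whether methoxy keeps that number when a fluoro is present on the same ring.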